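The source may report more compounds than this note shows. Statements on the series, on what has been measured and on what is new or still open speak of the compounds shown alone.

In a functional assay on LS174T cells (Homo sapiens) for inhibition, read by MTT assay, with a stated time of 72 h (a higher number here means a weaker inhibitor, a lower number a stronger inhibitor), compound 1 `CC(C)c1ccc(C(=O)/C=C/C(=O)O)cc1` gives 25700 nM and compound 2 `O=C(O)/C=C/C(=O)C1CCc2ccccc2C1` gives 17600 nM, two values within the scatter of each other, while compound 3 `CC(C)c1ccc(C(=O)/C=C/C(=O)O)c(C(C)C)c1` gives 5360 nM. Compound 4 `O=C(O)/C=C/C(=O)c1ccc(F)cc1` differs from compound 1 as follows: fluoro in place of isopropyl on an aromatic carbon. Among the compounds with values here, only one measured step bears on this change, a 4.8-fold lower number from compound 1 to compound 3 (0.68 log units; beyond the scatter), where isopropyl replaces hydrogen on an aromatic carbon. That step adds a group rather than exchanging one, so it is only weak guidance, but it suggests a slightly higher number once isopropyl leaves. The expected change is small, a 1.4-fold higher number from compound 1 to compound 4 (0.15 log units; within the scatter), and no firm shift beyond the scatter is anticipated. For compound 4 the estimated value is 36000 nM, with an expected range of 15000 nM to 85000 nM.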

Compound 4, half-maximal inhibitory concentration: 33800 nM
Estimate against measurement, compound 4: 1.1-fold (0.03 log units) above; low and high end bracket the measured number.
By their numbers in this assay, from the lowest: compound 3; then compounds 2, 1 and 4 (each within the scatter of the next).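

In this assay, fluoro in place of isopropyl on the aromatic carbon para to a group of 7 heavy atoms leaves the number within the scatter (a 1.3-fold higher number from compound 1 to compound 4 (0.12 log units; within the scatter)). Within the data shown here, the only earlier step added isopropyl at a different aromatic carbon, so this is the first reading of an exchange at this place. No evidence on hand bears on why the two groups read alike. Still open, from the compounds shown here alone, is whether an amine, a methoxy group or a longer alkyl chain at this place would move the number beyond the scatter.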